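Ester head group variation, compound 2 to compound 3

A few compounds are considered here, and "the series" means these few. Any claim that something is new, unique, unknown or untested is made for them only; others in the source may bear on it.

Among the measured compounds shown here, compound 2 `CCC(=O)OC1(C(=O)Nc2ccc([N+](=O)[O-])cc2)CCCCC1` gives 14.1 nM in a functional assay on MCF7 cells (Homo sapiens) for inhibition, read by MTT assay, with a stated time of 72 h (on this read-out higher numbers stand for weaker inhibition and lower numbers for stronger inhibition), the higher of the two numbers measured so far, while compound 1 `Cc1ccc(C(=O)OC2(C(=O)Nc3ccc([N+](=O)[O-])cc3)CCCCC2)cc1` gives 9.8 nM; the step from compound 1 to compound 2 is a 1.4-fold higher number from compound 1 to compound 2 (0.16 log units; within the scatter), so the two compounds cannot be separated on this read-out. Compound 3 `CC(=O)Oc1ccccc1C(=O)OC1(C(=O)Nc2ccc([N+](=O)[O-])cc2)CCCCC1` has not yet been measured. The change from compound 2 is 2-acetoxyphenyl in place of ethyl on a carbonyl carbon. For the measured compounds named here, the only measured step that bears on this exchange is a 1.4-fold higher number from compound 1 to compound 2 (0.16 log units; within the scatter), in which an aromatic ester group was traded for a short chain without any shift beyond the scatter; compound 3 puts an aromatic ester group back in, carrying an acetoxy substituent that no measured pair addresses. On that basis no step beyond the scatter is expected in this assay, the step from compound 2 to compound 3 being estimated as a 1.4-fold lower number from compound 2 to compound 3 (0.15 log units; within the scatter). Compound 3 is therefore expected to give 10 nM, with a range from 4 nM to 30 nM that allows for the untested acetoxy group.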

Compound 3, half-maximal inhibitory concentration: 16.9 nM
Estimate against measurement, compound 3: 1.7-fold (0.23 log units) below, and the stated range covers the measured number.
By their numbers in this assay, from the lowest: compounds 1, 2 and 3 (each within the scatter of the next).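

In this assay, the place on a carbonyl carbon whose other neighbour is oxygen next to a carbonyl group accepts 2-acetoxyphenyl in place of ethyl with a 1.2-fold higher number from compound 2 to compound 3 (0.08 log units; within the scatter), so a group of 10 heavy atoms with one six-membered aromatic ring and 2 hydrogen-bond acceptors cannot be separated from a 2-carbon chain on this read-out. Among the compounds shown here, exchanging one aromatic group for another gives the same picture, with a 1.7-fold higher number from compound 1 to compound 3 (0.24 log units; within the scatter); this extends the flat result of the first pair to a group carrying an acetoxy substituent, which neither compound 1 nor compound 2 has. No supporting measurement is available to explain this flat result.

All three compounds share the same core and vary only at this place, so the compounds shown say nothing about changes elsewhere in the structure. Going by these compounds, it also remains open whether an amine, a carboxylic acid or a longer chain at this place would produce a step beyond the scatter, or whether the acetoxy group of compound 3 could be replaced by a hydroxyl group without such a step.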